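A Chloro Step from Compound 1 to Compound 3

This account rests on a few compounds, and the source may have more. Where it says the series, first, only, none or still open, it means among the compounds named here.

In an ADME assay on RAW264.7 cells (Mus musculus) for cytotoxicity, read by MTT assay, with a stated time of 72 h, tested at 100 uM (a lower number here means a weaker effect, a higher number a stronger effect of the compound at the concentration tested), compound 1 `O=C(Cn1c(=O)oc2ccccc21)Nc1nc2ccccc2s1` gives 59.6%. Compound 2 `O=C(Cn1c(=O)oc2cc(Cl)ccc21)Nc1ccccc1` gives 20.2% in this assay. For the measured compounds named here, compound 1 stands highest of the two numbers, with compound 2 sitting a gap beyond the scatter below it; the two differ in more than one place, so no single step links them. Compound 3 `O=C(Cn1c(=O)oc2cc(Cl)ccc21)Nc1nc2ccccc2s1` has not yet been measured in this assay. It differs from compound 1 by chloro in place of hydrogen on an aromatic carbon. Going by the values given here, no measured pair differs by this change alone, so the size of the step is open, and compound 2 carries the chloro together with a different amide partner and cannot serve as a guide. The expected step is a number 9.6 percentage points lower from compound 1 to compound 3 (within the scatter), a modest fall or none beyond the scatter. For compound 3 in this assay the estimate is 50%, within 25% to 72%.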

Compound 3, a percentage reported as inhibition, at one concentration (the size of the read-out at that concentration, not a potency): 52.5%
The estimate for compound 3 lay 2.5 percentage points below the measured number; the measured number falls inside the stated range.
By their numbers in this assay, from the lowest: compound 2; then compounds 3 and 1 (each within the scatter of the next).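

Chloro in place of hydrogen at this position, meta to a fused ring and para to a fused ring, now has a direct reading in this assay: the change gives a number 7.1 percentage points lower from compound 1 to compound 3 (within the scatter) and so leaves the read-out of the core of compound 1 unmoved beyond the usual scatter. Compound 3 shares this chloro with compound 2, yet compound 3 gives 52.5% while compound 2 gives 20.2%, so the chloro alone does not bring the number down to that of compound 2. No measured evidence on the reason bears on this result.

On these data alone, it remains open whether an amine or a methoxy group at the same position would read as the chloro does. Also open, as far as these compounds go, is whether the chloro step would be equally small with the amide partner of compound 2.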